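The compounds below may be only part of what the source reports. "The series", "measured", "known", "first", "only" and "open" are said of these compounds alone.

Compound 1 `CC1=CCC[C@@H]2[C@@](C)(C[C@H](O)C3=CCOC3=O)[C@H](C)CC[C@@]12C`: 2.9 ug/mL
Compound 2 `CC1=CCC[C@@H]2[C@@](C)(C[C@H](O)C3=CC(=O)O[C@H]3O)[C@H](C)CC[C@@]12C`: 2.4 ug/mL

In an ADME assay on Lu1 cells (Homo sapiens) for cytotoxicity (a lower number here means that less compound is needed, a higher number that more compound is needed for the effect), compound 2 gives 2.4 ug/mL, while compound 1 gives 2.9 ug/mL; the step of a 1.2-fold lower number from compound 1 to compound 2 (0.08 log units; within the scatter) shows the two lie within the scatter of each other. Compound 3 `CC1=CCC[C@@H]2[C@@](C)(CCC3=CC(=O)O[C@H]3O)[C@H](C)CC[C@@]12C` differs from compound 2 by hydrogen in place of hydroxy on a saturated chain carbon bound to a double-bonded ring carbon and a saturated chain carbon. Going by the values given here, no measured step touches this place; the single step known, a 1.2-fold lower number from compound 1 to compound 2 (0.08 log units; within the scatter), altered a different group and stayed within the scatter. No step beyond the scatter is therefore expected in this assay. Compound 3 is expected to give about 2.6 ug/mL, between 1.2 ug/mL and 5.5 ug/mL. The expected step is a 1.1-fold higher number from compound 2 to compound 3 (0.03 log units; within the scatter).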

Compound 3, concentration for half-maximal effect: 3.7 ug/mL
The estimate for compound 3 lay 1.4-fold (0.15 log units) below the measured number, within the range that was stated.
By their numbers in this assay, from the lowest: compounds 2, 1 and 3 (each within the scatter of the next).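

Going by these compounds alone, this is the first look at this position, the saturated chain carbon bound to a double-bonded ring carbon and a saturated chain carbon. In this assay hydrogen in place of hydroxy there gives a 1.5-fold higher number from compound 2 to compound 3 (0.19 log units; within the scatter) and so the hydroxy can be absent without a step beyond the scatter. No measurement at hand offers an explanation for this result. From the compounds shown here alone, what stays open is whether a larger group on this carbon, such as an amine, a carboxylic acid or a longer chain, would produce a step beyond the scatter.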